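The source may hold more compounds than are shown below. What is called first, only, known or untested is meant among the compounds shown, and "the series" means these compounds.

Compound 1 `O=C1C(=Cc2ccc(O)cc2)C(=O)N(c2ccc(Cl)cc2)N1c1ccc(Cl)cc1` gives 34200 nM
Compound 2 `O=C1C(=Cc2c[nH]c3ccccc23)C(=O)N(c2ccc(Cl)cc2)N1c1ccc(Cl)cc1` gives 23400 nM

In a functional assay on ECa-109 cells (Homo sapiens) for cytotoxicity, read by MTT assay, with a stated time of 72 h (on this read-out higher numbers stand for weaker inhibition and lower numbers for stronger inhibition), compound 2 gives 23400 nM and so lies within the scatter of compound 1, which means the two cannot be ranked. The next molecule, compound 3 `O=C1C(=Cc2ccccc2)C(=O)N(c2ccc(Cl)cc2)N1c1ccc(Cl)cc1`, carries phenyl in place of 1H-indol-3-yl on a double-bonded chain carbon bound to a double-bonded ring carbon.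

Within the data shown here, only one measured step bears on this change. Among the measured compounds shown here, it is the one other exchange made at that same place. There, 4-hydroxyphenyl gave way to 1H-indol-3-yl (a 1.5-fold lower number from compound 1 to compound 2 (0.16 log units; within the scatter)). With that single step inside the scatter, no step beyond the scatter is expected for compound 3 in this assay either. One step is a thin basis for any forecast, so the range has to stay wide. The estimated step (a 1.3-fold higher number from compound 2 to compound 3 (0.11 log units; within the scatter)) is therefore small and is expected to stay inside the scatter. For compound 3 the estimated value is 30000 nM with an expected range (13000 nM to 65000 nM).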

Compound 3, half-maximal inhibitory concentration: 32700 nM
Estimate against measurement, compound 3: 1.1-fold (0.04 log units) below, and the stated range covers the measured number.
By their numbers in this assay, from the lowest: compounds 2, 3 and 1 (each within the scatter of the next).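

In this assay, the change from the two-ring 1H-indol-3-yl to the single-ring phenyl on a double-bonded chain carbon bound to a double-bonded ring carbon gives a 1.4-fold higher number from compound 2 to compound 3 (0.15 log units; within the scatter) and so stays within the scatter, even though the group loses a ring and its hydrogen-bond donor. The third compound also allows a second, narrower comparison: hydrogen in place of hydroxy on an aromatic carbon gives a 1.0-fold lower number from compound 1 to compound 3 (0.02 log units; within the scatter) and likewise cannot be told apart from no change, so plain phenyl, 4-hydroxyphenyl and 1H-indol-3-yl cannot be ranked at this position in this cell assay. Nothing measured alongside these numbers offers a reason for this flat result.

On these data alone, all three groups tried here are aromatic rings, so it remains open whether an amine or a carboxylic acid on the ring, or a longer chain in its place, would produce a step beyond the scatter. As far as these compounds go, it also remains open whether changes elsewhere on the shared core would move the number more than the changes at this position have.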